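Two Fluorines on the Phenyl Ring of a Triazole Amide

The source may hold more compounds than are shown below. What is called first, only, known or untested is meant among the compounds shown, and "the series" means these compounds.

Compound 1 `COc1cc2c(Oc3ccc(NC(=O)c4cn(-c5ccccc5)nn4)cc3F)ccnc2cc1OCCCN1CCN(C)CC1` and compound 2 `COc1cc2c(Oc3ccc(NC(=O)c4cn(-c5ccccc5F)nn4)cc3F)ccnc2cc1OCCCN1CCN(C)CC1` share one core and differ in a single fluorine on the phenyl ring attached to the triazole. In a functional assay on HT-29 cells (Homo sapiens) for cytotoxicity, read by MTT assay, with a stated time of 72 h (on this read-out lower numbers stand for stronger inhibition and higher numbers for weaker inhibition), compound 1 gives 180 nM, while compound 2 gives 300 nM. Compound 2 thus has the higher of the two numbers, but the gap to compound 1 is within the scatter. Compound 3 `COc1cc2c(Oc3ccc(NC(=O)c4cn(-c5ccc(F)c(F)c5)nn4)cc3F)ccnc2cc1OCCCN1CCN(C)CC1` carries 3,4-difluorophenyl in place of 2-fluorophenyl on an aromatic nitrogen. Among the measured compounds shown here, the only measured step that bears on this change is the addition of one fluorine to the same phenyl ring, a 1.7-fold higher number from compound 1 to compound 2 (0.22 log units; within the scatter), which produced no shift beyond the scatter. Adding a second fluorine and moving the first is therefore expected to leave the number near that of compound 2. Compound 3 is expected to give about 350 nM in this assay, with a range from 150 nM to 800 nM. The expected change, a 1.2-fold higher number from compound 2 to compound 3 (0.07 log units; within the scatter), stays within the scatter.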

Compound 3, half-maximal inhibitory concentration: 430 nM
The estimate for compound 3 lay 1.2-fold (0.09 log units) below the measured number; the range from low to high includes it.
By their numbers in this assay, from the lowest: compounds 1, 2 and 3 (each within the scatter of the next, the first and the last beyond it).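

In this assay the change on the aromatic nitrogen gives a 1.4-fold higher number from compound 2 to compound 3 (0.16 log units; within the scatter) and so does not separate the 3,4-difluorophenyl group from the 2-fluorophenyl group. Set against the plain phenyl group, the same 3,4-difluorophenyl group gives a 2.4-fold higher number from compound 1 to compound 3 (0.38 log units; beyond the scatter) and is the first change at this position to pass beyond the scatter, although the step is modest. Nothing available explains this step.

The compounds shown change the number and the place of the fluorines together, so the separate contribution of each remains unknown. As far as these compounds go, it also remains open how a phenyl ring carrying a methoxy group, an amine or a carboxylic acid instead of fluorine would compare.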